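The source may hold more compounds than are shown below. What is called first, only, known or untested is meant among the compounds shown, and "the series" means these compounds.

Three related compounds have been examined in an ADME assay on A549 cells (Homo sapiens) for cytotoxicity, read by resazurin assay, with a stated time of 48 h; a lower number here means that less compound is tolerated, a higher number that more compound is tolerated. Compound 1, with the structure `O=C(Nc1ccc(NCc2ccccc2)cc1Cl)c1cc(Cl)ccc1O`, gives 19700 nM in this assay. Compound 2, with the structure `O=C(Nc1ccc(NCc2ccc(F)cc2)cc1Cl)c1cc(Cl)ccc1O`, carries fluoro in place of hydrogen on an aromatic carbon and gives 54400 nM in this assay; this change brought a 2.8-fold higher number from compound 1 to compound 2 (0.44 log units; beyond the scatter). Compound 3, with the structure `O=C(Nc1ccc(NC2CCCC2)cc1)c1cc(Cl)ccc1O`, gives 10000 nM in this assay, a number within the scatter of compound 1 and separated from compound 2 by a gap that lies beyond the scatter. How the core of compound 3 differs from the core of compound 1 is not broken down here.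

Compound 4, with the structure `O=C(Nc1ccc(NC2CCCC2)cc1F)c1cc(Cl)ccc1O`, has not yet been measured. It carries fluoro in place of hydrogen on an aromatic carbon. This is the same kind of change as that from compound 1 to compound 2, but not the same change: in compound 2 the fluoro sits para to a large group, whereas in compound 4 it sits ortho to a large group and meta to a cyclopentylamino group. Within the data shown here, the one measured example of this kind of change, the step from compound 1 to compound 2, was modest and beyond the scatter. On that basis a step of a 1.7-fold higher number from compound 3 to compound 4 (0.23 log units; within the scatter) is expected from compound 3 to compound 4 in this assay, somewhat smaller than the measured one given the different surroundings of the fluoro. Compound 4 is therefore estimated at 17000 nM in this assay, with a likely range from 7000 nM to 45000 nM.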

Compound 4, half-maximal cytotoxic concentration: 51000 nM
The estimate for compound 4 lay 3.0-fold (0.48 log units) below the measured number, and the stated range ends below it.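

In this assay, fluoro in place of hydrogen on an aromatic carbon again brought more tolerance, with a 5.1-fold higher number from compound 3 to compound 4 (0.71 log units; beyond the scatter). Set beside the earlier step, the new one points the same way and cannot be told apart from it in size: the same change on two cores in this assay, a 2.8-fold higher number (0.44 log units; beyond the scatter) from compound 1 to compound 2 and a 5.1-fold higher number (0.71 log units; beyond the scatter) from compound 3 to compound 4, 1.8-fold (0.27 log units) apart, within the scatter of two such steps. This shows that, on these two cores, the change carried over in direction even though the fluoro sits in a different place on each, but two steps make no rule for other cores, and they do not show why the number rises or separate the part played by the core from the part played by the position of the fluoro.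

The compounds shown leave open whether the rise belongs to fluoro itself or would also appear with another group on the aromatic carbon that carries the fluoro in compound 4, such as a methyl, a methoxy or a nitrile. They also leave open how fluoro would behave on a core with a different amine part, for example a morpholine or a longer alkyl chain in place of the cyclopentylamino group of compound 4.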